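Benzylsulfanyl series, metabolic half-life notes: chloro on the benzyl

A few compounds are considered here, and "the series" means these few. Any claim that something is new, unique, unknown or untested is made for them only; others in the source may bear on it.

Measured so far:
- compound 1, `Cc1cc(S(=O)(=O)/N=C(\N)N/N=C/C#Cc2ccccc2)c(SCc2ccccc2)cc1Cl`, in an ADME assay on microsomes from liver (Homo sapiens) for metabolic stability, read by LC-MS, using NADPH, tested at 5 uM (a higher number here means that the compound lasts longer, a lower number that the compound disappears faster), compound 1 gives 0.469 h
- compound 2, `C/C(C#Cc1ccccc1)=N\N/C(N)=N/S(=O)(=O)c1cc(C)c(Cl)cc1SCc1cccc(C(F)(F)F)c1`, in this assay compound 2 gives 0.13 h

Compound 1 stands highest of the two numbers; compound 2, which carries a trifluoromethyl on the benzyl ring and a methyl on the imine carbon, lies beyond the scatter below it. The two differ in more than one place, so no single step can be read from them.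

Compound 3, `Cc1cc(S(=O)(=O)/N=C(\N)N/N=C/C#Cc2ccccc2)c(SCc2ccccc2Cl)cc1Cl`, is the next compound. It differs from compound 1 only in chloro in place of hydrogen on an aromatic carbon, that is, the benzylsulfanyl becomes (2-chlorobenzyl)sulfanyl. Within the data shown here, no pair measured so far isolates a substituent on this ring. Compound 2 gives 0.13 h, the only hint that a substituted benzyl may sit lower. The step from compound 1 to compound 3 is expected to be a 1.3-fold lower number from compound 1 to compound 3 (0.13 log units; within the scatter), a small decrease or none beyond the scatter. Compound 3 is estimated at 0.35 h, range 0.15 h to 0.8 h.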

Compound 3, half-life: 0.254 h
For compound 3 the middle estimate is 1.4-fold (0.14 log units) above the measured one; low and high end bracket the measured number.
By their numbers in this assay, from the lowest: compounds 2, 3 and 1 (each within the scatter of the next, the first and the last beyond it).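

Among these compounds, this pair is the first to isolate a substituent on the benzyl ring. In this assay the change from benzyl to 2-chlorobenzyl gives a 1.8-fold lower number from compound 1 to compound 3 (0.27 log units; within the scatter) and so stays within the scatter. On this single pair, chloro on this aromatic carbon, ortho to a large group, cannot be told apart from hydrogen in half-life. No measurement at hand bears on this step.

Open, on these data alone, is whether a methoxy, an amine or a carboxylic acid on the same carbon would give a step beyond the scatter, and whether chloro elsewhere on this ring would read the same. Also open, as far as these compounds go, is whether the chloro step holds in compounds with a methyl on the imine carbon.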